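The compounds below may be only part of what the source reports. "The series", "measured", "known", "first", "only" and "open" are said of these compounds alone.

Compound 1 `COc1ccccc1C(=O)NC(=O)Nc1ccc(N2CCCCC2)c(Cl)c1` carries a chloro group on the aromatic ring that also bears the piperidin-1-yl group. In an ADME assay on LLC-PK1 cells (Sus scrofa) for permeability (a higher number here means that the compound crosses the layer faster, a lower number that the compound crosses the layer more slowly), compound 1 gives only a limit of the assay, < 1 10^-6 cm/s, and not a number. Its standing on the numbers shown is therefore fixed only by the limit of < 1 10^-6 cm/s in this assay, at which 1 of the 2 values shown sits. Among the compounds with values here, compound 2 `COc1ccccc1C(=O)NC(=S)Nc1ccc(N2CCCCC2)c(Cl)c1`, the thiourea counterpart, is the only compound of the series with a numerical reading: in this assay compound 2 gives 1.8 10^-6 cm/s. Within the data shown here, no pair of measured compounds differs in a single place, so no measured step is available to calibrate the change to compound 3 `COc1ccccc1C(=O)NC(=O)Nc1ccc(N2CCCCC2)c(C(F)(F)F)c1`. The change from compound 1 to compound 3 is trifluoromethyl in place of chloro on an aromatic carbon. Among the measured compounds shown here, with no measured step to lean on, the expectation for this assay is a step not beyond the scatter, if anything slightly upward, an at least 1.2-fold higher number from compound 1 to compound 3 (0.07 log units; that floor lies within the scatter). For compound 3 the estimated apparent permeability is 1.2 10^-6 cm/s, with a range from 0.5 10^-6 cm/s to 3 10^-6 cm/s.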

Compound 3, apparent permeability: < 1 10^-6 cm/s
Compound 3 ended at the assay's limit; the forecaster's own chance of this, stated with the estimate: 40%; middle value at least 1.2-fold (0.07 log units) from the limit.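

Compound 1 and compound 3 both sit at a limit of this assay rather than at a number, so no step between them can be read: the limit of < 1 10^-6 cm/s in this assay, at which 2 of the 3 values shown sit.

As far as these compounds go, whether trifluoromethyl in place of chloro shifts the reading in this assay at all, and in which direction, remains open.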